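The source may report more compounds than this note shows. Statements on the series, on what has been measured and on what is new or still open speak of the compounds shown alone.

Two members of the series carry values in an ADME assay on MRC5 cells (Homo sapiens) for cytotoxicity, read by MTT assay, with a stated time of 96 h; on this read-out higher numbers stand for an effect only at larger amounts of compound and lower numbers for an effect already at smaller amounts. Compound 1 `CC(=O)/C(=C/c1c(-c2ccccc2)[nH]c2ccccc12)C(=O)c1ccccc1` gives > 100000 nM in this assay, which is a limit of the assay and not a number; this entry is the limit of > 100000 nM in this assay, at which 1 of the 2 values shown sits. Compound 2 `N#C/C(=C\c1c(-c2ccccc2)[nH]c2ccccc12)C(=O)c1cccs1` gives 20000 nM in this assay, the only number shown so far. Going by the values given here, no pair of measured compounds differs in one place, so no measured step exists to rest on. Compound 3 `COCCOC(=O)/C(C#N)=C/c1c(-c2ccccc2)[nH]c2ccccc12` has not yet been measured in this assay. It differs from compound 2 by 2-methoxyethoxy in place of thiophen-2-yl on a carbonyl carbon, in words 2-methoxyethoxy in place of thiophen-2-yl on a carbonyl carbon, or, cut one bond further out, (thiophen-2-yl)carbonyl to (2-methoxyethoxy)carbonyl. For compound 3 the expected step is a 1.8-fold higher number from compound 2 to compound 3 (0.24 log units; within the scatter), a small move, if anything toward a higher number, likely not beyond the scatter. The estimate for compound 3 in this assay is 35000 nM, with a range from 10000 nM to 120000 nM.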

Compound 3, half-maximal effective concentration: > 100000 nM
Compound 3 ended at the assay's limit; the forecaster's own chance of this, stated with the estimate: 30%; at least 2.8-fold (0.45 log units) between middle value and limit.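

In this assay, this carbonyl position now has its first measured change: 2-methoxyethoxy in place of thiophen-2-yl gives an at least 5.0-fold higher number from compound 2 to compound 3 (0.69 log units; beyond the scatter), so the group on this carbon can shift the read-out beyond the scatter. Compound 3 gives > 100000 nM, which is a limit of the assay and not a number, so the full size of the step cannot be read. Compound 3 joins compound 1 at that limit, leaving compound 2 as the only compound with a number: the limit of > 100000 nM in this assay, at which 2 of the 3 values shown sit.

On these data alone, whether the number seen for compound 2 depends on thiophen-2-yl in particular or on having a ring on this carbonyl carbon stays open. A phenyl group, a plain methoxy group or an amine in the same place could separate these readings.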